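This account rests on a few compounds, and the source may have more. Where it says the series, first, only, none or still open, it means among the compounds named here.

Measured compounds:
compound 1, `COc1cc(-c2ccnc3cc(-c4ccc(Cl)cc4)nn23)cc(OC)c1OC`: 3340 nM
compound 2, `COc1cc(-c2ccnc3cc(-c4ccc5cc[nH]c5c4)nn23)cc(OC)c1OC`: 187 nM
compound 3, `COc1cc(-c2ccnc3cc(-c4ccc(C(C)=O)cc4)nn23)cc(OC)c1OC`: 4390 nM

These three share one core and differ only in the aryl group attached to it. In a functional assay on HCT-116 cells (Homo sapiens) for inhibition, read by CCK-8 assay, with a stated time of 48 h (on this read-out lower numbers stand for stronger inhibition and higher numbers for weaker inhibition), compound 1 stands second highest of the three numbers; its nearest neighbour is compound 3, which lies within the scatter, while the furthest is compound 2, which shows an 18-fold lower number from compound 1 to compound 2 (1.25 log units; beyond the scatter). Compound 4, `COc1cc(-c2ccnc3cc(-c4cccc(C)c4)nn23)cc(OC)c1OC`, is the next member and is not yet measured in this assay. Its change from compound 1 is 3-methylphenyl in place of 4-chlorophenyl on an aromatic carbon. The most telling earlier step is a 1.3-fold higher number from compound 1 to compound 3 (0.12 log units; within the scatter), where swapping one substituent on the same phenyl ring for another moved the number only within the scatter; the large shift only appeared when the whole ring was replaced, as in an 18-fold lower number from compound 1 to compound 2 (1.25 log units; beyond the scatter). Since compound 4 keeps a plain phenyl ring with a single small substituent, no step beyond the scatter is expected from compound 1 to compound 4. The estimate for compound 4 is 3000 nM, with a range from 1000 nM to 9000 nM, which means an expected step of a 1.1-fold lower number from compound 1 to compound 4 (0.05 log units; within the scatter).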

Compound 4, half-maximal inhibitory concentration: 6150 nM
Compound 4: the middle estimate sits 2.1-fold (0.31 log units) below what was measured; measured number inside the range.
By their numbers in this assay, from the lowest: compound 2; then compounds 1, 3 and 4 (each within the scatter of the next).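

In this assay the 3-methylphenyl group gives a 1.8-fold higher number from compound 1 to compound 4 (0.27 log units; within the scatter) when it replaces 4-chlorophenyl and a 1.4-fold higher number from compound 3 to compound 4 (0.15 log units; within the scatter) when it replaces 4-acetylphenyl on this aromatic carbon. A third substituted phenyl ring therefore joins the other two within the scatter, even with the methyl named at a different ring number. Going by these compounds alone, the 1H-indol-6-yl group remains apart, with a 33-fold higher number from compound 2 to compound 4 (1.52 log units; beyond the scatter) as the largest step so far. No measurement here accounts for that gap. Still open, on these data alone, is whether a phenyl ring carrying an amine or a carboxylic acid would stay with the phenyl compounds or approach compound 2.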